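Side-chain swap on the free acid: compound 3 to compound 4

The source may hold more compounds than are shown below. What is called first, only, known or untested is meant among the compounds shown, and "the series" means these compounds.

compound 1 `CSCC[C@H](NC(=O)CN(c1nc(Cl)nc2[nH]cnc12)C1CC1)C(=O)OCc1ccccc1` — 31.6%
compound 2 `CC[C@H](C)[C@H](NC(=O)CN(c1nc(Cl)nc2[nH]cnc12)C1CC1)C(=O)OCc1ccccc1` — 22%
compound 3 `CSCC[C@H](NC(=O)CN(c1nc(Cl)nc2[nH]cnc12)C1CC1)C(=O)O` — 5.67%

In a functional assay on the whole organism (Tail, strain ICR) with Mus musculus as the target, in the tail flick test, with a stated time of 120 min, at a dose of 25 umol/kg by the oral route (a lower number here means a weaker effect, a higher number a stronger effect of the compound at the dose given), compound 3 gives 5.67%, the lowest of the three numbers; compound 1 sits above it by a number 25.9 percentage points lower from compound 1 to compound 3 (beyond the scatter), and the value of compound 2 also lies above it. Compound 4 `NC(=O)C[C@H](NC(=O)CN(c1nc(Cl)nc2[nH]cnc12)C1CC1)C(=O)O` differs from compound 3 by carbamoyl in place of (methylsulfanyl)methyl on a saturated chain carbon, two bonds along the chain from an amide-type nitrogen and a carbonyl carbon. Among the compounds with values here, the only measured step at this side chain is a number 9.6 percentage points lower from compound 1 to compound 2 (within the scatter), a sec-butyl for 2-(methylsulfanyl)ethyl exchange that stayed within the scatter. Nothing measured shows a carbamoyl group at this place. On that basis the step in this assay from compound 3 to compound 4 is expected to be a number 0.3 percentage points higher from compound 3 to compound 4 (within the scatter), that is, none beyond the scatter. Compound 4 is therefore estimated at 6%, within a range of 0% to 18%.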

Compound 4, a percentage reported as activity, at one dose (the size of the read-out at that dose, not a potency): 17%
The estimate for compound 4 lay 11 percentage points below the measured number, within the range that was stated.
By their numbers in this assay, from the lowest: compound 3; then compounds 4, 2 and 1 (each within the scatter of the next, the first and the last beyond it).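

In this assay the side chain at this position can move the number on the free acid: carbamoyl in place of (methylsulfanyl)methyl gives a number 11.3 percentage points higher from compound 3 to compound 4 (beyond the scatter) as a modest change. The earlier step at this side chain, on the benzyl esters, was a number 9.6 percentage points lower from compound 1 to compound 2 (within the scatter) and showed no such change. No evidence at hand bears on the reason for this step.

Still open, on these data alone, is whether the carbamoyl exchange reads the same on a benzyl ester. Also open, as far as these compounds go, is how a longer chain, an amine or a carboxylic acid at this place would compare.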